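From iodo to carboxy in a closely matched series

This account rests on a few compounds, and the source may have more. Where it says the series, first, only, none or still open, it means among the compounds named here.

In an ADME assay on MDCK cells (Canis lupus familiaris) for cytotoxicity, read by sulforhodamine B assay, with a stated time of 48 h (a lower number here means a stronger inhibitor, a higher number a weaker inhibitor), compound 1 `O=c1cc(-c2ccccc2)oc2cc(OCCCCNc3nc4ccccc4s3)cc(O)c12` gives 348 ug/mL, compound 2 `O=c1cc(-c2ccccc2)oc2cc(OCCCCNc3nc4ccc(Br)cc4s3)cc(O)c12` gives 289 ug/mL, and compound 3 `O=c1cc(-c2ccccc2)oc2cc(OCCCCNc3nc4ccc(I)cc4s3)cc(O)c12` gives 298 ug/mL. Compound 3 therefore stands level with the other two, within the scatter of both. The next compound is compound 4 `O=C(O)c1ccc2nc(NCCCCOc3cc(O)c4c(=O)cc(-c5ccccc5)oc4c3)sc2c1`, which carries carboxy in place of iodo on an aromatic carbon. Three measured steps change the group at this same place. Bromo in place of hydrogen gives a 1.2-fold lower number from compound 1 to compound 2 (0.08 log units; within the scatter), iodo in place of hydrogen gives a 1.2-fold lower number from compound 1 to compound 3 (0.07 log units; within the scatter), and iodo in place of bromo gives a 1.0-fold higher number from compound 2 to compound 3 (0.01 log units; within the scatter). Within the data shown here, none of these steps leaves the scatter, although no measured compound yet carries a carboxy group, so the guide is only partial. No step beyond the scatter is therefore expected in this assay, and the expected change is a 1.0-fold higher number from compound 3 to compound 4 (0.02 log units; within the scatter). The estimated value for compound 4 is 310 ug/mL, with an expected range from 170 ug/mL to 560 ug/mL.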

Compound 4, half-maximal inhibitory concentration: 324 ug/mL
Beside the measured number, compound 4's estimate is 1.0-fold (0.02 log units) below it; the range from low to high includes it.
By their numbers in this assay, from the lowest: compounds 2, 3, 4 and 1 (each within the scatter of the next).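

Carboxy in place of iodo stays within the scatter in this assay (a 1.1-fold higher number from compound 3 to compound 4 (0.04 log units; within the scatter)), as does carboxy in place of bromo (a 1.1-fold higher number from compound 2 to compound 4 (0.05 log units; within the scatter)) and carboxy in place of hydrogen (a 1.1-fold lower number from compound 1 to compound 4 (0.03 log units; within the scatter)). Iodo carries no hydrogen-bond donor or acceptor and carboxy carries one of each, so among these four compounds this place on the aromatic ring takes a group of a different kind, not only another halogen, with no step beyond the scatter. No measurement shown explains this flat result.

From the compounds shown here alone, whether an amine or a methoxy group at this same place would also stay within the scatter remains open. So does whether a longer chain between the two ring systems would leave the number as unmoved as these changes do.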